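The compounds below may be only part of what the source reports. "The series", "measured", "known", "first", "only" and "open" are said of these compounds alone.

Four compounds share one core and differ in two spots: the group hanging from an amide-type nitrogen, and whether the other neighbour of that nitrogen is a carbonyl carbon or a thiocarbonyl carbon. Compound 1 `CC1(C)CC(NC(=O)NCc2ccccc2)c2cc(Br)ccc2O1` carries a benzyl group on a nitrogen whose other neighbour is a carbonyl carbon. Compound 2 `CC1(C)CC(NC(=S)NCc2ccccc2)c2cc(Br)ccc2O1` carries the same benzyl group, but on a nitrogen whose other neighbour is a thiocarbonyl carbon. Compound 3 `CC1(C)CC(NC(=O)Nc2ccc(Cl)cc2)c2cc(Br)ccc2O1` has a 4-chlorophenyl group beside the carbonyl carbon, and compound 4 `CC1(C)CC(NC(=S)Nc2ccc(Cl)cc2)c2cc(Br)ccc2O1`, not yet measured, has the 4-chlorophenyl group beside the thiocarbonyl carbon.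

In a functional assay on T98G cells (Homo sapiens) for inhibition, read by MTT assay, with a stated time of 72 h (on this read-out lower numbers stand for stronger inhibition and higher numbers for weaker inhibition), compound 1 gives 38000 nM, compound 2 gives 54000 nM and compound 3 gives 27000 nM. The three numbers lie within the usual scatter of one another, so no order among them can be read. The change 4-chlorophenyl in place of benzyl on an amide-type nitrogen made the step of a 1.4-fold lower number from compound 1 to compound 3 (0.15 log units; within the scatter). How the core of compound 2 differs from that of compound 1 is not broken down here; the values of compound 1 and compound 2 simply sit close together.

The change 4-chlorophenyl in place of benzyl on an amide-type nitrogen is the same kind of change, but at a nitrogen whose other neighbour is a thiocarbonyl carbon rather than a carbonyl carbon. Because the earlier step of a 1.4-fold lower number from compound 1 to compound 3 (0.15 log units; within the scatter) stayed within the scatter, compound 4 is expected to move by about a 1.4-fold lower number from compound 2 to compound 4 (0.13 log units; within the scatter) in this assay. Compound 4 is therefore estimated at 40000 nM, with a likely range from 18000 nM to 90000 nM.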

Compound 4, half-maximal inhibitory concentration: 22000 nM
Estimate against measurement, compound 4: 1.8-fold (0.26 log units) above, and the stated range covers the measured number.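

Replacing benzyl with 4-chlorophenyl on an amide-type nitrogen whose other neighbour is a thiocarbonyl carbon gives, in this assay, a 2.5-fold lower number from compound 2 to compound 4 (0.39 log units; beyond the scatter), a modest step. Set beside the same replacement at the carbonyl carbon, this step does not differ from the earlier one by more than the scatter of two such steps, so in these four compounds the change carries over from one core to the other: the same change on two cores in this assay, a 1.4-fold lower number (0.15 log units; within the scatter) from compound 1 to compound 3 and a 2.5-fold lower number (0.39 log units; beyond the scatter) from compound 2 to compound 4, 1.7-fold (0.24 log units) apart, within the scatter of two such steps. For the compounds shown here, this does not prove that the step is exactly the same size on both cores, and two pairs of compounds are too few to make a rule for the wider series, even though only the step on the thiocarbonyl core lies beyond the scatter.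

The compounds shown leave open whether the carry-over would hold for other groups on that nitrogen, such as a longer chain like 2-phenylethyl, a 4-methoxyphenyl group, or a phenyl ring bearing an amine or a carboxylic acid. They also leave open whether the same step would appear if chlorine took the place of the bromine on the shared core.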